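Thiosemicarbazone analogues: from compound 2 to compound 4

A few compounds are considered here, and "the series" means these few. Any claim that something is new, unique, unknown or untested is made for them only; others in the source may bear on it.

Of the compounds shown here, three sharing one core have been measured in a functional assay on HCT-116 cells (Homo sapiens) for antiproliferative activity, read by MTT assay, with a stated time of 72 h; on this read-out lower numbers stand for stronger inhibition and higher numbers for weaker inhibition. Compound 1 `NC(=S)N/N=C1/C=C(Nc2ccccc2Cl)C(Nc2ccccc2Cl)=NC1=O` gives 3540 nM. Compound 2 `NC(=S)N/N=C1/C=C(Nc2cccc(Cl)c2)C(Nc2cccc(Cl)c2)=NC1=O` gives 3380 nM, the lowest of the three numbers, although its value and that of compound 1 lie within the scatter of each other and no order between them can be read. Compound 3 `NC(=S)N/N=C1/C=C(Nc2cccc([N+](=O)[O-])c2)C(Nc2cccc([N+](=O)[O-])c2)=NC1=O` gives 19400 nM, a number that stands beyond the scatter from that of compound 2.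

Compound 4 `N/C(=N\N=C1\C=C(Nc2cccc(Cl)c2)C(Nc2cccc(Cl)c2)=NC1=O)SCc1ccccc1` has not yet been measured in this assay. It differs from compound 2 in one place: a group of 11 heavy atoms (8 carbon, 2 nitrogen, 1 sulfur; one six-membered aromatic ring of carbon only) in place of a group of 4 heavy atoms (1 carbon, 2 nitrogen, 1 sulfur; no ring), on a double-bonded nitrogen. For the measured compounds named here, no pair of measured compounds in this set differs at that position, so there is no step on record from which the size or direction of this change can be read. The expectation for compound 4 rests on compound 2 giving 3380 nM and on the absence of any measured precedent for the change; the step from compound 2 to compound 4 is estimated as a 1.1-fold lower number from compound 2 to compound 4 (0.02 log units; within the scatter), with no direction beyond the scatter claimed. Compound 4 is accordingly expected to give about 3200 nM in this assay, within a range from 800 nM to 13000 nM.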

Compound 4, half-maximal inhibitory concentration: 11700 nM
Estimate against measurement, compound 4: 3.7-fold (0.56 log units) below; the measured number falls inside the stated range.
By their numbers in this assay, from the lowest: compounds 2 and 1 (each within the scatter of the next); then compounds 4 and 3 (each within the scatter of the next).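

In this assay, the change at this position, on a double-bonded nitrogen whose other neighbour is a carbon with a double bond to nitrogen, now has a step on record: the group of 11 heavy atoms with its six-membered aromatic ring, in place of the group of 4 heavy atoms with no ring, gives a 3.5-fold higher number from compound 2 to compound 4 (0.54 log units; beyond the scatter). Compounds 1, 2 and 3 all carry the same group here, so they could say nothing about this position; the new step shows that the read-out does respond to a change at it, while compound 4 still gives a measured number, 11700 nM. Nothing on hand bears on what in this change lies behind the step.

On these data alone, one step cannot separate the effect of the ring from that of the rest of the change, so it stays open how a methyl group or a longer chain in place of the ring, or an amine or a carboxylic acid carried on it, would read. As far as these compounds go, it also stays open whether the same change would give a step of like size with the aromatic groups of compound 1 or compound 3 in place.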